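Swapping a Methyl for Trifluoromethyl on the Ring

A few compounds are considered here, and "the series" means these few. Any claim that something is new, unique, unknown or untested is made for them only; others in the source may bear on it.

Three measured compounds share one core and differ only in the ring attached to the amide nitrogen. Compound 1 `CC(C)[C@H](C(=O)Nc1nncs1)c1ccc(Cl)cc1` gives 12000 nM in a functional assay on CHO cells for agonist activity at Free fatty acid receptor 2 (Homo sapiens), read by cAMP accumulation; a higher number here means a weaker inhibitor, a lower number a stronger inhibitor. Compound 2 `CC(C)[C@H](C(=O)NC1=NC(=O)CS1)c1ccc(Cl)cc1` gives 20000 nM in this assay, and a 1.7-fold higher number from compound 1 to compound 2 (0.22 log units; within the scatter). Compound 3 `Cc1csc(NC(=O)[C@H](c2ccc(Cl)cc2)C(C)C)n1` gives 1400 nM in this assay, the lowest of the three numbers. Both steps toward it are clear: an 8.6-fold lower number from compound 1 to compound 3 (0.93 log units; beyond the scatter), and a 14-fold lower number from compound 2 to compound 3 (1.15 log units; beyond the scatter). Compound 4 `CC(C)[C@H](C(=O)Nc1nc(C(F)(F)F)cs1)c1ccc(Cl)cc1` keeps the ring of compound 3 and alters one group on it: trifluoromethyl in place of methyl on an aromatic carbon. Among the compounds with values here, none of the measured steps bears directly on this change; each of them exchanged the whole ring rather than a group on it. The steps that reach compound 3 show that the ring matters, but they give no guide for a substituent swap on that ring. The expectation is therefore a step that stays within the scatter in either direction, a 1.1-fold higher number from compound 3 to compound 4 (0.03 log units; within the scatter). Compound 4 is expected to give 1500 nM in this assay, within a range from 400 nM to 6000 nM.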

Compound 4, half-maximal inhibitory concentration: 17000 nM
Compound 4: the middle estimate sits 11-fold (1.05 log units) below what was measured; the measured number lies above the stated range.
By their numbers in this assay, from the lowest: compound 3; then compounds 1, 4 and 2 (each within the scatter of the next).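

This position on the ring is far from neutral: with the ring itself kept, exchanging one group gives a 12-fold higher number from compound 3 to compound 4 (1.08 log units; beyond the scatter) in this assay, so methyl and trifluoromethyl are not interchangeable here. Within the data shown here, the earlier steps exchanged whole rings and showed only that the ring matters, whereas this step shows that a single group on the aromatic carbon next to the ring nitrogen can also move the number beyond the scatter. Nothing measured here explains why the number rises with this swap.

The compounds shown leave open how other groups on this carbon would read, such as an ethyl chain, a chlorine atom or an amine, and where the same ring with only hydrogen there would fall. They also leave open whether this swap would move the number similarly on a different core.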